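The source may hold more compounds than are shown below. What is called first, only, known or untested is meant among the compounds shown, and "the series" means these compounds.

Compound 2 `COc1ccc(-n2cc(COc3ccc(/C=C/C(C)=O)cc3OC)nn2)cc1` stands lowest of the two numbers in a functional assay on HCT-116 cells (Homo sapiens) for antiproliferative activity, read by MTT assay, with a stated time of 48 h (a higher number here means a weaker inhibitor, a lower number a stronger inhibitor), at 21300 nM. Compound 3 `COc1cc(/C=C/C(C)=O)ccc1OCc1cn(-c2ccc(C(F)(F)F)c(C(F)(F)F)c2)nn1` gives 57800 nM in this assay. Compound 1 `COc1cc(/C=C/C(C)=O)ccc1OCc1cn(-c2ccc(/N=N/c3ccccc3)cc2)nn1` reaches only the limit of this assay, > 100000 nM; this is the limit of > 100000 nM in this assay, at which 1 of the 3 values shown sits. Within the data shown here, the one step measured in one place, an at least 4.6-fold lower number from compound 1 to compound 2 (0.67 log units; beyond the scatter), shows that the ring substituent on the five-membered ring matters here.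

Compound 4 `COc1cc(/C=C/C(C)=O)ccc1OCc1cn(-c2ccccc2O)nn1` differs from compound 2 by 2-hydroxyphenyl in place of 4-methoxyphenyl on an aromatic nitrogen. Among the measured compounds shown here, no measured step swaps two phenyl substituents of similar size in this way; the measured step concerns a far larger exchange, so it bears only loosely on the present one. The small shift of a single oxygen group around the phenyl ring, with a hydrogen-bond donor entering, is expected to leave the number near that of compound 2, at most a small rise. Compound 4 is therefore estimated at 30000 nM in this assay, within 10000 nM to 90000 nM, which means an expected step of a 1.4-fold higher number from compound 2 to compound 4 (0.15 log units; within the scatter).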

Compound 4, half-maximal inhibitory concentration: 76400 nM
Beside the measured number, compound 4's estimate is 2.5-fold (0.41 log units) below it, within the range that was stated.
By their numbers in this assay, from the lowest: compound 2; then compounds 3 and 4 (each within the scatter of the next). At a limit, above all of these: compound 1.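

In this assay, a 3.6-fold higher number from compound 2 to compound 4 (0.55 log units; beyond the scatter) shows that the substituent on the aromatic nitrogen of the five-membered ring affects the number even when one phenyl group replaces another of similar size, whereas the earlier step covered only a far larger exchange. Of these two groups, 4-methoxyphenyl gives the lower number. The change from 4-methoxyphenyl to 2-hydroxyphenyl alters the place of the oxygen group and its kind together and brings in a hydrogen-bond donor, and nothing at hand bears on the cause of the step.

The compounds shown leave open which of these changes carries the step. They also leave open how an amine or a carboxylic acid on the phenyl ring, in place of the oxygen group, would compare.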